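Urea to benzamide on a shared core: an opening

A few compounds are considered here, and "the series" means these few. Any claim that something is new, unique, unknown or untested is made for them only; others in the source may bear on it.

Compound 1 `O=C(Nc1ccccc1)Nc1ccc(-c2ccccc2)cn1` gives 20% in an assay on isolated protein (Aquatica lateralis) for inhibition of Luciferin 4-monooxygenase (Luciola lateralis), read by a luciferase reporter, tested at 10 uM; on this read-out higher numbers stand for more inhibition at the one concentration tested (going by the name of the read-out) and lower numbers for less inhibition.
Compound 2 `O=C(Nc1ccc(-c2ccc(Cl)c(Cl)c2)cn1)c1ccccc1` gives 4% in this assay.

Going by the values given here, of the two compounds measured so far, compound 1 stands highest; compound 2 lies lower by a gap that goes beyond the usual scatter, and no step between these two compounds is computed, so only their two values can be read side by side. Compound 3 `Cc1ccc(C(=O)Nc2ccc(-c3ccccc3)cn2)cc1` is not yet measured. It differs from compound 1 in one place: 4-methylphenyl in place of anilino on a carbonyl carbon. The carbonyl carbon thus keeps its amide-type nitrogen neighbour on one side, while on the other side a 4-methylphenyl replaces the anilino group.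

Among the compounds with values here, no measured pair isolates this change, so the expectation rests on the two values alone. Compound 2, which also carries a carbonyl bearing an aryl group rather than an anilino, gives 4%, and this suggests a modest downward step in this assay that may well stay within the scatter. The expected step is a number 8 percentage points lower from compound 1 to compound 3 (within the scatter). The estimate for compound 3 is 12%, with a range from 0% to 30%.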

Compound 3, a percentage reported as inhibition, at one concentration (the size of the read-out at that concentration, not a potency): 18%
For compound 3 the middle estimate is 6 percentage points below the measured one; measured number inside the range.
By their numbers in this assay, from the lowest: compound 2; then compounds 3 and 1 (each within the scatter of the next).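

Going by these compounds alone, the step from the urea to the amide is now isolated for the first time: in this assay, putting 4-methylphenyl in place of anilino on a carbonyl carbon gives a number 2 percentage points lower from compound 1 to compound 3 (within the scatter), so this read-out does not separate the two compounds. At this position, then, the anilino with its hydrogen-bond donor and the 4-methylphenyl with none can be exchanged without a change that stands clear of the scatter, at the one concentration tested. Nothing measured here speaks to why the two groups read alike.

From the compounds shown here alone, it remains open whether any group on this carbonyl carbon would move the number beyond the scatter, for example a butyl chain, a cyclohexyl or a 4-carboxyphenyl on the core of compound 1. Going by these compounds, it also remains open what the methyl of the 4-methylphenyl contributes, and whether these two compounds would still read alike as full potencies rather than as inhibition at a single concentration.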